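Replacing 3-fluorophenyl with cyclopentyl on the amine nitrogen

A few compounds are considered here, and "the series" means these few. Any claim that something is new, unique, unknown or untested is made for them only; others in the source may bear on it.

Measured so far, in a functional assay on ECa-109 cells for inhibition, with ECa-109 cell line (Homo sapiens) as the target, read by sulforhodamine B assay; on this read-out lower numbers stand for stronger inhibition and higher numbers for weaker inhibition:
- compound 1 `O=C1C=C(Nc2ccccc2F)C(=O)c2c1nc1n2[C@H]2OC[C@@H](O)[C@H]2OC1`: 2760 nM
- compound 2 `O=C1C=C(Nc2cccc(F)c2)C(=O)c2c1nc1n2[C@H]2OC[C@@H](O)[C@H]2OC1`: 7030 nM

Compound 2 holds the higher number of the two, at 7030 nM, and thus the weaker inhibition. Among the measured compounds shown here, the only neighbour available for comparison is compound 1, at 2760 nM. The next compound to read is compound 3 `O=C1C=C(NC2CCCC2)C(=O)c2c1nc1n2[C@H]2OC[C@@H](O)[C@H]2OC1`, which keeps the shared core and carries cyclopentyl in place of 3-fluorophenyl on an amine nitrogen.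

For the measured compounds named here, only one measured step bears on this change, and only loosely. It is a 2.5-fold higher number from compound 1 to compound 2 (0.41 log units; beyond the scatter), a modest step beyond the scatter, with 3-fluorophenyl in place of 2-fluorophenyl. That step keeps the aromatic ring, whereas the change to compound 3 removes it, so the data give no measured case of this replacement and no firm direction. A step of similar or somewhat larger size in this assay remains plausible either way, so the range stays wide, with only a slight lean towards a lower number.

For compound 3 the expected value is 5000 nM, with an estimated range of 1500 nM to 15000 nM. The expected change is a 1.4-fold lower number from compound 2 to compound 3 (0.15 log units; within the scatter).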

Compound 3, half-maximal inhibitory concentration: > 16000 nM
Compound 3: no number, only a limit (the forecaster's own chance of this, stated with the estimate: 3%); middle value at least 3.2-fold (0.50 log units) away from the limit.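

In this assay compound 3 gives no number, only a limit of the assay: the limit of > 16000 nM in this assay, at which 1 of the 3 values shown sits.

Even read as a limit, the change on the amine nitrogen has a clear direction, with an at least 2.2-fold higher number from compound 2 to compound 3 (0.35 log units; beyond the scatter), and against the other fluorophenyl compound, an at least 5.7-fold higher number from compound 1 to compound 3 (0.76 log units; beyond the scatter). Among the compounds shown here, the earlier pair showed only what moving the fluorine on a phenyl ring does, from 2-fluorophenyl to 3-fluorophenyl; this is the first change at the position that replaces the aromatic ring itself, and it goes towards weaker inhibition from both fluorophenyl compounds. As far as these compounds go, the true size of both steps stays open-ended, so the move from an aryl to a cycloalkyl group is at least as costly as the printed steps, and possibly far more so, which makes it a larger effect than the shift of the fluorine.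

The compounds shown leave open whether the loss follows from giving up the aromatic ring or is particular to cyclopentyl, a point that plain phenyl, benzyl or cyclohexyl on the same nitrogen would help to separate. Also open, from the compounds shown here alone, is how an open chain such as n-butyl, or a chain ending in an amine, would read at this position.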